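A Single Methyl Carried Over to a Second Core

The source may report more compounds than this note shows. Statements on the series, on what has been measured and on what is new or still open speak of the compounds shown alone.

Compound 1 `CC(C)=CCCC1=CCC2=C(C1)C(=O)C=CC2=O` and compound 3 `CC(C)=CCCc1ccc2c(c1)C(=O)C=CC2=O` carry the same chain on two different cores; the difference between the two cores is not broken down here. In a functional assay on HT-29 cells (Homo sapiens) for cytotoxicity (a lower number here means a stronger inhibitor, a higher number a weaker inhibitor), compound 1 gives 2100 nM, and compound 3 gives 1000 nM. Compound 2 `CC(C)=CCCC1=CCC2=C(C1)C(=O)C(C)=CC2=O` differs from compound 1 by methyl in place of hydrogen on a double-bonded ring carbon. In this assay compound 2 gives 19500 nM. That step is a 9.3-fold higher number from compound 1 to compound 2 (0.97 log units; beyond the scatter). Compound 4 `CC(C)=CCCc1ccc2c(c1)C(=O)C(C)=CC2=O` carries the same kind of change on the core of compound 3, (methyl in place of hydrogen on a double-bonded ring carbon); around the place, compound 2 is also described with two ring bonds and three ring bonds from the ring atom that bears a fused ring, which is not stated for compound 4. Because a 9.3-fold higher number from compound 1 to compound 2 (0.97 log units; beyond the scatter) was seen with compound 1 and compound 2, a step of about an 8.0-fold higher number from compound 3 to compound 4 (0.90 log units; beyond the scatter) is expected for the methyl on compound 3. Compound 4 is therefore estimated at 8000 nM, expected to fall between 3000 nM and 25000 nM.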

Compound 4, half-maximal inhibitory concentration: 19600 nM
Beside the measured number, compound 4's estimate is 2.5-fold (0.39 log units) below it; low and high end bracket the measured number.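

In this assay, methyl in place of hydrogen on a double-bonded ring carbon gives a 20-fold higher number from compound 3 to compound 4 (1.29 log units; beyond the scatter) on the second core. The size of this step does not differ from that of the earlier one beyond the scatter: the same change on two cores in this assay, a 9.3-fold higher number (0.97 log units; beyond the scatter) from compound 1 to compound 2 and a 20-fold higher number (1.29 log units; beyond the scatter) from compound 3 to compound 4, 2.1-fold (0.32 log units) apart, within the scatter of two such steps. The change therefore carries over between these two cores in both direction and size, but this pair alone does not show why the methyl has this effect or whether the same would hold on any other core.

The compounds shown leave open how an ethyl group, an amine or a carboxylic acid at the same place would compare with hydrogen and methyl. They also leave open whether a longer chain would alter the step.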